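Moving the Trifluoromethyl Group Around the Aryl Ring

A few compounds are considered here, and "the series" means these few. Any claim that something is new, unique, unknown or untested is made for them only; others in the source may bear on it.

Among the measured compounds shown here, compound 3 `COC(=O)/C(=C/c1ccccc1)CN1C(=O)[C@@H](OC)[C@H]1c1ccc(OC)cc1` is measured in a functional assay on MDA-MB-231 cells (Homo sapiens) for antiproliferative activity, read by MTT assay, with a stated time of 48 h (on this read-out lower numbers stand for stronger inhibition and higher numbers for weaker inhibition), at 14000 nM, which places it second highest of the three numbers so far; compound 2 `COC(=O)/C(=C/c1ccccc1)CN1C(=O)[C@@H](OC)[C@H]1c1ccccc1` gives 11100 nM and compound 1 `COC(=O)/C(=C/c1ccccc1)CN1C(=O)[C@@H](OC)[C@H]1c1cccc(C(F)(F)F)c1` gives 18200 nM. Compound 4 `COC(=O)/C(=C/c1ccccc1)CN1C(=O)[C@@H](OC)[C@H]1c1ccccc1C(F)(F)F` differs from compound 3 in one place: 2-(trifluoromethyl)phenyl in place of 4-methoxyphenyl on a saturated ring carbon. For the measured compounds named here, the closest precedent is the reverse exchange a 1.3-fold lower number from compound 1 to compound 3 (0.11 log units; within the scatter); the smaller swaps a 1.6-fold lower number from compound 1 to compound 2 (0.21 log units; within the scatter) and a 1.3-fold higher number from compound 2 to compound 3 (0.10 log units; within the scatter) also stayed within the scatter. All three measured compounds sit close together, so the aryl group appears to matter little among them. The step of a 1.1-fold higher number from compound 3 to compound 4 (0.06 log units; within the scatter) is therefore expected to be nothing beyond the scatter. Compound 4 is estimated at 16000 nM, with a range from 7000 nM to 36000 nM.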

Compound 4, half-maximal inhibitory concentration: 17600 nM
For compound 4 the middle estimate is 1.1-fold (0.04 log units) below the measured one; low and high end bracket the measured number.
By their numbers in this assay, from the lowest: compounds 2, 3, 4 and 1 (each within the scatter of the next).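

Swapping 3-(trifluoromethyl)phenyl for 2-(trifluoromethyl)phenyl in this assay gives a 1.0-fold lower number from compound 1 to compound 4 (0.01 log units; within the scatter) and so shows that moving the trifluoromethyl group around this aryl ring leaves the number within the scatter. Adding that group in place of hydrogen gives a 1.6-fold higher number from compound 2 to compound 4 (0.20 log units; within the scatter) and the exchange for 4-methoxyphenyl gives a 1.3-fold higher number from compound 3 to compound 4 (0.10 log units; within the scatter) so neither change stands out from the scatter either. No supporting data bear on why this position appears so flat.

As far as these compounds go, whether an amine or a carboxylic acid on the aryl ring would move the number beyond the scatter stays open. So does whether a longer chain in place of the aryl ring would do so.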